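The compounds below may be only part of what the source reports. "The series", "measured", "known", "first", "only" and "open" are said of these compounds alone.

Measured so far in a functional assay on HOS-TE85 cells (Homo sapiens) for inhibition, read by CCK-8 assay, with a stated time of 72 h; a lower number here means a stronger inhibitor, a higher number a weaker inhibitor:
- Compound 1 `COc1ccc(C)cc1N1C(=O)CSC1c1cccc(C(=O)NCCCCc2ccccc2)c1`: 300 nM
- Compound 2 `O=C(NCCCCn1cccn1)c1cccc(C2SCC(=O)N2c2cccnc2)c1`: > 1000 nM

Compound 2 reads > 1000 nM, which is a limit of the assay and not a number. Among the compounds with values here, it therefore has no exact position, and the only numerical value so far belongs to compound 1.

Compound 3 `O=C(NCCCCn1cccn1)c1cccc(C2SCC(=O)N2c2ccncc2)c1` is the next to be read, and it departs from compound 2 by a single change: pyridin-4-yl in place of pyridin-3-yl on an amide-type nitrogen in a ring. In words, this is pyridin-4-yl in place of pyridin-3-yl on an amide-type nitrogen in a ring. Within the data shown here, no measured step covers this change, so no direction can be assigned in this assay, and no step beyond the scatter is expected. The expected size is a step that the limit leaves unreadable from compound 2 to compound 3. The estimate for compound 3 is 1500 nM, with an expected range of 500 nM to 6000 nM.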

Compound 3, half-maximal inhibitory concentration: > 1000 nM
Compound 3: a limit, no number (the forecaster's own chance of this, stated with the estimate: 60%); the middle value does not contradict the limit.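

No new step can be read between compound 2 and compound 3, whose values in this assay are limits of the assay and not numbers: the limit of > 1000 nM in this assay, at which 2 of the 3 values shown sit.

Left open is whether pyridin-4-yl and pyridin-3-yl on the amide-type nitrogen differ at all in this assay.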